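Swapping the Outer Ring on a Sulfonamide Core

This account rests on a few compounds, and the source may have more. Where it says the series, first, only, none or still open, it means among the compounds named here.

Going by the values given here, in a functional assay on DLD-1 cells (Homo sapiens) for antiproliferative activity, read by CellTiter-Glo, with a stated time of 72 h (on this read-out lower numbers stand for stronger inhibition and higher numbers for weaker inhibition), compound 1 `CC1CCN(C2CCN(S(=O)(=O)c3cccc(-c4ccccc4C(F)(F)F)c3)CC2)CC1` gives 10 nM, the lowest of the three numbers measured so far. Its nearest neighbour is compound 2 `COc1ccccc1-c1ccc(S(=O)(=O)N2CCC(N3CCC(C)CC3)CC2)cc1`, which gives 26 nM, a gap beyond the usual scatter. Furthest away is compound 3 `CC1CCCN(C2CCN(S(=O)(=O)c3ccc(OC(F)F)cc3)CC2)C1`, which gives 105 nM.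

Compound 4 `COc1ccc(-c2cccc(S(=O)(=O)N3CCC(N4CCC(C)CC4)CC3)c2)cc1` has not yet been measured in this assay. It differs from compound 1 in one place: 4-methoxyphenyl in place of 2-(trifluoromethyl)phenyl on an aromatic carbon. The leaving group carries fluorine and no hydrogen-bond acceptor; the entering group carries one oxygen acceptor, placed meta to a large group.

The step of a 3.0-fold higher number from compound 1 to compound 4 (0.48 log units; beyond the scatter) is expected to weaken inhibition moderately, since compound 2 with 26 nM also carries a methoxy group and stands above compound 1. Compound 4 is therefore expected to give about 30 nM, within a range from 10 nM to 90 nM.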

Compound 4, half-maximal inhibitory concentration: 23 nM
For compound 4 the middle estimate is 1.3-fold (0.12 log units) above the measured one; low and high end bracket the measured number.
By their numbers in this assay, from the lowest: compound 1; then compounds 4 and 2 (each within the scatter of the next); then compound 3.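

Going by these compounds alone, this is the first comparison here that changes only one place: on this aromatic carbon, 4-methoxyphenyl in place of 2-(trifluoromethyl)phenyl gives a 2.3-fold higher number from compound 1 to compound 4 (0.36 log units; beyond the scatter) in this assay. The step is modest, so at this place a ring without fluorine and with one oxygen acceptor still leaves a measurable but limited loss of inhibition. Nothing available explains the size of this step.

The swap changes both the substituent and where it sits on the outer ring, so these two changes cannot be told apart. From the compounds shown here alone, it remains open how a 4-(trifluoromethyl)phenyl group, or an outer ring carrying an amine or a carboxylic acid, would compare at this place.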